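This account rests on a few compounds, and the source may have more. Where it says the series, first, only, none or still open, it means among the compounds named here.

Measured in an ADME assay on MIA PaCa-2 cells (Homo sapiens) for cytotoxicity, read by MTT assay, with a stated time of 72 h; on this read-out higher numbers stand for weaker inhibition and lower numbers for stronger inhibition:
- compound 1 `COc1ccc(C2=C(c3cc(OC)c(OC)c(OC)c3)C(=O)CC2O[SiH2]C(C)(C)C)cc1` gives > 100 ug/mL (a limit)
- compound 2 `COc1ccc(C2=C(c3cc(OC)c(OC)c(OC)c3)C(=O)CC2O)cc1O` gives > 100 ug/mL (a limit)
- compound 3 `COc1cc(C2=C(c3ccc(OCC(=O)O)cc3)C(O)CC2=O)cc(OC)c1OC` gives > 100 ug/mL (a limit)

For compound 3 the value > 100 ug/mL is a limit of the assay and not a number. The whole set shows the limit of > 100 ug/mL in this assay, at which 3 of the 3 values shown sit, and nothing finer, so compound 3 cannot be ranked against the other two.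

Compound 4 `COc1ccc(C2=C(c3cc(OC)c(OC)c(OC)c3)C(=O)CC2O)cc1` is reached from compound 3 by one structural change, (hydrogen in place of carboxy on a saturated chain carbon bound to an oxygen on an aromatic ring), which in words is hydrogen in place of carboxy on a saturated chain carbon bound to an oxygen on an aromatic ring. Cut one bond further out, it reads carboxymethoxy to methoxy.

For the measured compounds named here, no measured pair differs in just one place, so no direct guide to the size of this step exists. Compound 2 also lacks a carboxy group and still gives > 100 ug/mL as a limit, so removing that group is not expected to bring strong inhibition. The expected change is an at least 1.2-fold lower number from compound 3 to compound 4 (0.09 log units; that floor lies within the scatter) and it may be no more than a small move toward stronger inhibition. For compound 4 the estimated value in this assay is 80 ug/mL within an expected range of 20 ug/mL to 200 ug/mL and the assay may well report only a limit again.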

Compound 4, half-maximal inhibitory concentration: > 100 ug/mL
Compound 4 gave a limit, no number; the forecaster's own chance of this, stated with the estimate: 60%; middle value at least 1.2-fold (0.09 log units) from the limit.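

Compound 4 gives > 100 ug/mL, a limit and not a number. The steps to compound 4 from compound 1, compound 2 and compound 3 cannot be read, because all four compounds sit at the same limit: the limit of > 100 ug/mL in this assay, at which 4 of the 4 values shown sit.

The compounds shown leave open whether any of these structural changes alters inhibition of these cells at all.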